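Working notes: aryl change on the amide-type nitrogen

A few compounds are considered here, and "the series" means these few. Any claim that something is new, unique, unknown or untested is made for them only; others in the source may bear on it.

Measured in an ADME assay on MT4 cells (Homo sapiens) for cytotoxicity, read by MTT assay, with a stated time of 5 days; on this read-out lower numbers stand for higher toxicity in this test and higher numbers for lower toxicity in this test:
- Compound 1 `COc1cc2nc([S+]([O-])CC(=O)Nc3cccc(F)c3)nc(Nc3c(Cl)cc(/C=C/C#N)cc3Cl)c2cc1OC`: 9550 nM.
- Compound 2 `COc1cc2nc([S+]([O-])CC(=O)Nc3ccc(C(F)(F)F)cc3)nc(Nc3c(Cl)cc(/C=C/C#N)cc3Cl)c2cc1OC`: 22000 nM.
- Compound 3 `COc1cc2nc([S+]([O-])CC(=O)Nc3ccc(C#N)cc3)nc(Nc3c(Cl)cc(/C=C/C#N)cc3Cl)c2cc1OC`: >= 188000 nM, a limit and not a number.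

Only a limit is known for compound 3: the limit of >= 188000 nM in this assay, at which 1 of the 3 values shown sits. The change to compound 4 `COc1cccc(NC(=O)C[S+]([O-])c2nc(Nc3c(Cl)cc(/C=C/C#N)cc3Cl)c3cc(OC)c(OC)cc3n2)c1` is 3-methoxyphenyl in place of 4-cyanophenyl on an amide-type nitrogen.

Going by the values given here, three measured steps bear on this. an at least 19-fold higher number from compound 1 to compound 3 (1.29 log units; beyond the scatter) is large and an at least 8.5-fold higher number from compound 2 to compound 3 (0.93 log units; beyond the scatter) is at least modest, and both end at the 4-cyanophenyl compound. a 2.3-fold higher number from compound 1 to compound 2 (0.36 log units; beyond the scatter) is modest, and it joins the two compounds that lack the 4-cyanophenyl group. Compound 4 also lacks that group, so it is expected to fall near compound 1 and compound 2 rather than near compound 3.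

The expected change is an at least 9.4-fold lower number from compound 3 to compound 4 (0.97 log units; beyond the scatter), a large step to a lower number in this assay. For compound 4 the estimate is 20000 nM, with an expected range of 5000 nM to 90000 nM.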

Compound 4, half-maximal cytotoxic concentration: >= 167000 nM
Compound 4 ended at the assay's limit; the forecaster's own chance of this, stated with the estimate: 15%; middle value at least 8.3-fold (0.92 log units) away from the limit.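

In this assay compound 4 gives a limit and not a number, and 4-cyanophenyl is therefore not the only group on the amide-type nitrogen with such a result: the limit of >= 167000 nM in this assay, at which 1 of the 4 values shown sits.

Methoxy in place of fluoro on an aromatic carbon gives an at least 17-fold higher number from compound 1 to compound 4 (1.24 log units; beyond the scatter), a large change from one group alone, and 3-methoxyphenyl in place of 4-(trifluoromethyl)phenyl gives an at least 7.5-fold higher number from compound 2 to compound 4 (0.88 log units; beyond the scatter). The step between compound 3 and compound 4 cannot be read.

As far as these compounds go, the true values of compound 3 and compound 4 stay open, and no order between them can be given. Also open, from the compounds shown here alone, is how an amine or a carboxylic acid in place of the methoxy group would read in this assay.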